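Swapping the Aryl Group on an Acrylamide Side Chain

The source may report more compounds than this note shows. Statements on the series, on what has been measured and on what is new or still open speak of the compounds shown alone.

Compound 1, `O=C(/C=C/c1cccc(Cl)c1Cl)Nc1cc2c(Nc3ccc(F)c(Cl)c3)ncnc2cc1O[C@H]1CCOC1`: 27500 nM
Compound 2, `N#Cc1ccc(/C=C/C(=O)Nc2cc3c(Nc4ccc(F)c(Cl)c4)ncnc3cc2O[C@H]2CCOC2)cc1`: 36600 nM

Of the two numbers measured in a functional assay on PC-3 cells (Homo sapiens) for cytotoxicity, read by MTT assay, with a stated time of 72 h (on this read-out lower numbers stand for stronger inhibition and higher numbers for weaker inhibition), compound 2 stands at the upper end, but the step of a 1.3-fold higher number from compound 1 to compound 2 (0.12 log units; within the scatter) is within the scatter, so the two compounds cannot be told apart. Compound 3, `COc1cc(/C=C/C(=O)Nc2cc3c(Nc4ccc(F)c(Cl)c4)ncnc3cc2O[C@H]2CCOC2)cc(OC)c1`, is not yet measured. It differs from compound 2 in one place: 3,5-dimethoxyphenyl in place of 4-cyanophenyl on a double-bonded chain carbon bound to a double-bonded chain carbon. Among the measured compounds shown here, the only measured step, a 1.3-fold higher number from compound 1 to compound 2 (0.12 log units; within the scatter), also changed the group on a double-bonded chain carbon bound to a double-bonded chain carbon and stayed within the scatter. The expected step is therefore a 1.1-fold lower number from compound 2 to compound 3 (0.04 log units; within the scatter), nothing beyond the scatter. For compound 3 in this assay the estimate is 33000 nM, between 12000 nM and 90000 nM.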

Compound 3, half-maximal inhibitory concentration: 25600 nM
Compound 3: middle estimate off by 1.3-fold (0.11 log units), on the high side; measured number inside the range.
By their numbers in this assay, from the lowest: compounds 3, 1 and 2 (each within the scatter of the next).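

In this assay the 3,5-dimethoxyphenyl group gives a 1.4-fold lower number from compound 2 to compound 3 (0.16 log units; within the scatter) and a 1.1-fold lower number from compound 1 to compound 3 (0.03 log units; within the scatter) with both steps within the scatter. Three differently substituted phenyl groups at this position, now including one that carries oxygen, therefore cannot be told apart. No other data bear on this result.

All three groups are phenyl rings, so the compounds shown leave open whether a group of another kind on a double-bonded chain carbon bound to a double-bonded chain carbon, such as an amine, a carboxylic acid or a longer chain, would step beyond the scatter.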